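The source may hold more compounds than are shown below. What is called first, only, known or untested is meant among the compounds shown, and "the series" means these compounds.

For the measured compounds named here, of the two numbers so far in a functional assay on isolated protein for inhibition of Glucose-dependent insulinotropic receptor (Rattus norvegicus), read by HTRF and cAMP accumulation (a lower number here means that less compound is needed, a higher number that more compound is needed for the effect), the one for compound 2 `Cc1nc(S(C)(=O)=O)ccc1Oc1ncnc(OC2CCN(C(=O)c3nc(C(C)(C)F)no3)CC2)c1F`, which gives 606 nM, is the highest, though only within the scatter of compound 1 `CCC1(OC(=O)N2CCC(Oc3ncnc(Oc4ccc(S(C)(=O)=O)nc4C)c3F)CC2)CC1`, which in this assay gives 333 nM. Compound 3 `Cc1nc(S(C)(=O)=O)ccc1Oc1ncnc(OC2CCN(C(=O)c3ncc(Cl)cn3)CC2)c1F` differs from compound 2 by a group of 7 heavy atoms (4 carbon, 2 nitrogen, 1 chlorine; one six-membered aromatic ring with 2 hetero atoms) in place of a group of 9 heavy atoms (5 carbon, 2 nitrogen, 1 oxygen, 1 fluorine; one five-membered aromatic ring with 3 hetero atoms), on a carbonyl carbon. Going by the values given here, the one measured step bearing on this position is a 1.8-fold higher number from compound 1 to compound 2 (0.26 log units; within the scatter), another exchange of the group on the carbonyl carbon that stayed within the scatter. No step beyond the scatter is therefore expected: a 1.3-fold lower number from compound 2 to compound 3 (0.13 log units; within the scatter). Compound 3 is estimated at 450 nM, with a range from 150 nM to 1400 nM.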

Compound 3, half-maximal effective concentration: 30.9 nM
The estimate for compound 3 lay 15-fold (1.16 log units) above the measured number; measured number below the stated range.
By their numbers in this assay, from the lowest: compound 3; then compounds 1 and 2 (each within the scatter of the next).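

At the carbonyl carbon, the group is not interchangeable in this assay: 5-chloropyrimidin-2-yl gives a 20-fold lower number from compound 2 to compound 3 (1.29 log units; beyond the scatter) and also an 11-fold lower number from compound 1 to compound 3 (1.03 log units; beyond the scatter) against the two groups it was compared with. The earlier exchange at this position stayed within the scatter, so compounds 1 and 2 gave no sign that this position could move the number this far. No evidence bears on what lies behind these steps.

The compounds shown do not separate the contribution of the chlorine from that of the pyrimidine ring. A pyrimidin-2-yl group without chlorine, or one carrying methyl or a nitrile in place of the chlorine, would address this.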